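Acetoxy-to-hydroxy change on the saturated ring carbon

The compounds below may be only part of what the source reports. "The series", "measured", "known", "first", "only" and "open" are said of these compounds alone.

Measured in an ADME assay on ECV-304 cells (Homo sapiens) for cytotoxicity, read by MTT assay, with a stated time of 72 h; on this read-out lower numbers stand for stronger inhibition and higher numbers for weaker inhibition:
compound 1, `COc1cc(C2=C(c3cc(C)c(OC)c(C)c3)C(O)CC2=O)cc(OC)c1OC`: > 100 ug/mL, a limit of the assay.
compound 2, `COc1cc(C2=C(c3cc(C)c(OC)c(C)c3)C(OC(C)=O)CC2=O)cc(OC)c1OC`: > 100 ug/mL, a limit of the assay.
compound 3, `CC(=O)OC1C/C(=N/O)C(c2ccccc2)=C1c1ccccc1`: > 100 ug/mL, a limit of the assay.

Compound 4, `O/N=C1/CC(O)C(c2ccccc2)=C1c1ccccc1`, is not yet measured in this assay. It differs from compound 3 by hydrogen in place of acetyl on an oxygen on a saturated carbon. The same change is made from compound 2 to compound 1: hydrogen in place of acetyl on an oxygen on a saturated carbon. The two place lines read the same word for word, so it is the same change on both cores. The difference between the two cores themselves, compound 2 against compound 3, is not broken down here.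

The measured instance of the change, a step that the two limits leave unreadable from compound 2 to compound 1, cannot be read because of the limit of > 100 ug/mL in this assay, at which 3 of the 3 values shown sit. Both ends sit at that limit, so the step carries no readable size and sets no direction for compound 4.

Within the data shown here, for compound 4 the step is expected to be a number no higher from compound 3 to compound 4 (the limit leaves the size open), resting only on the fact that compound 3 gives > 100 ug/mL and that the one measured instance of this change left compound 1 at a limit. Compound 4 is therefore estimated at 100 ug/mL, most likely reported again as a limit rather than a number, within 50 ug/mL to 200 ug/mL.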

Compound 4, half-maximal inhibitory concentration: > 100 ug/mL
Compound 4: a limit, no number; the forecaster's own chance of this, stated with the estimate: 85%; the middle value lies on the limit itself.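

In this assay, the acetoxy to hydroxy change from compound 3 to compound 4 yields no readable step, because both compounds sit at a limit of the assay: the limit of > 100 ug/mL in this assay, at which 4 of the 4 values shown sit.

The compounds shown leave open whether this change alters the read-out on either core, and how the two cores compare.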